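The source may hold more compounds than are shown below. What is called first, only, known or untested is meant among the compounds shown, and "the series" means these compounds.

Measured so far in an ADME assay on L6 cells (Rattus norvegicus) for cytotoxicity, read by resazurin assay, with a stated time of 72 h; a lower number here means a stronger inhibitor, a higher number a weaker inhibitor:
Compound 1 `OC(c1ccc(Cl)cc1)(c1cccnc1)c1ccccc1Cl` gives 61300 nM
Compound 2 `CC(C)Oc1ccccc1C(O)(c1ccc(Cl)cc1)c1cccnc1` gives 48300 nM
Compound 3 `OC(c1ccc(Cl)cc1)(c1cccnc1)c1ccccc1Br` gives 55200 nM

In this assay compound 3, at 55200 nM, lies within the scatter of both other compounds, so the three values show no order.

The unmeasured compound 4 `OC(c1ccc(Cl)cc1)(c1cccnc1)c1ccccc1C(F)(F)F` keeps the core of compound 3 and differs from it in one place: trifluoromethyl in place of bromo on an aromatic carbon. The change is trifluoromethyl in place of bromo on an aromatic carbon, ortho to a large group.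

Among the measured compounds shown here, three measured steps bear on this, as each exchanges the group at that same place. They are a 1.1-fold lower number from compound 1 to compound 3 (0.05 log units; within the scatter), a 1.1-fold higher number from compound 2 to compound 3 (0.06 log units; within the scatter) and a 1.3-fold lower number from compound 1 to compound 2 (0.10 log units; within the scatter). All three stay within the scatter, across chloro, bromo and isopropoxy. For the measured compounds named here, no measured compound carries trifluoromethyl, so the new group itself remains untested, and that limits how far these steps can be trusted. Even so, no step beyond the scatter is expected in this assay, and no direction is favoured.

The expected change is a 1.1-fold lower number from compound 3 to compound 4 (0.03 log units; within the scatter). For compound 4 the estimate is 52000 nM, with an expected range from 30000 nM to 85000 nM.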

Compound 4, half-maximal inhibitory concentration: 59300 nM
For compound 4 the middle estimate is 1.1-fold (0.06 log units) below the measured one, and the stated range covers the measured number.
By their numbers in this assay, from the lowest: compounds 2, 3, 4 and 1 (each within the scatter of the next).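

In this assay the position now carries a fourth group, and trifluoromethyl in place of bromo gives a 1.1-fold higher number from compound 3 to compound 4 (0.03 log units; within the scatter) with the rest of the molecule unchanged. The same group in place of isopropoxy gives a 1.2-fold higher number from compound 2 to compound 4 (0.09 log units; within the scatter) and in place of chloro gives a 1.0-fold lower number from compound 1 to compound 4 (0.01 log units; within the scatter), so the flat picture from chloro, bromo and isopropoxy at this place, on an aromatic carbon ortho to a large group, now takes in trifluoromethyl as well, with four heavy atoms entering where bromo had one, and the four compounds still fall in no order. The data shown offer no measurement that would account for this lack of response.

On these data alone, all four groups carry no charge and no hydrogen-bond donor, so it stays open whether an amine or a carboxylic acid at this place, or a longer chain such as a hexyloxy group, would give a step beyond the scatter. The rest of the shared core is the same in all four compounds, which leaves open how this number responds to a change anywhere else, such as at the hydroxyl group.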